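The source may report more compounds than this note shows. Statements on the series, on what has been measured and on what is new or still open speak of the compounds shown alone.

In a functional assay on HeLa cells (Homo sapiens) for cytotoxicity, read by MTT assay, with a stated time of 24 h (a higher number here means a weaker inhibitor, a lower number a stronger inhibitor), compound 2, the structure `C=CC1=C(C(=O)NC2CCCCC2)C(c2ccc(OC)c(OC)c2)OC1`, gives 5540 nM, the lowest of the two numbers in hand. Compound 3, the structure `C=CC1=C(C(=O)NC2CCCCC2)C(c2ccc(OC)cc2)OC1`, gives 24800 nM in this assay. Compound 1, the structure `C=CC1=C(C(=O)NCc2ccccc2)C(c2ccc(OC)c(OC)c2)OC1`, is reported only as a limit of this assay, > 100000 nM, so no number is available for it; the evidence the limit of > 100000 nM in this assay, at which 1 of the 3 values shown sits, covers this.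

The step to compound 4, the structure `C=CC1=C(C(=O)NCCC)C(c2ccc(OC)c(OC)c2)OC1`, makes one change: propyl in place of cyclohexyl on an amide-type nitrogen. The measured step that bears on it most is an at least 18-fold lower number from compound 1 to compound 2 (1.25 log units; beyond the scatter), which shows that what sits on the amide nitrogen matters strongly for this assay. The other step, a 4.5-fold higher number from compound 2 to compound 3 (0.65 log units; beyond the scatter), concerns the aromatic ring and is less relevant. Because the swap from benzyl to cyclohexyl gave an at least 18-fold lower number from compound 1 to compound 2 (1.25 log units; beyond the scatter), moving away from cyclohexyl to the shorter propyl chain is expected to raise the number beyond the scatter, by roughly a 3.6-fold higher number from compound 2 to compound 4 (0.56 log units; beyond the scatter). Compound 4 is therefore estimated at 20000 nM, within a range of 6000 nM to 70000 nM.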

Compound 4, half-maximal inhibitory concentration: > 100000 nM
Compound 4 ended at the assay's limit; the forecaster's own chance of this, stated with the estimate: 15%; middle value at least 5.0-fold (0.69 log units) away from the limit.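

Replacing cyclohexyl with propyl on the amide-type nitrogen gives an at least 18-fold higher number from compound 2 to compound 4 (1.25 log units; beyond the scatter) in this assay, and compound 4 stands at a limit of the assay rather than at a true number. Benzyl was already known to end at that limit, and now an open chain does too, so among the three groups shown on this nitrogen, only cyclohexyl gives a readable number. The step between compound 1 and compound 4 cannot be read, because both compounds end at the limit: the limit of > 100000 nM in this assay, at which 2 of the 4 values shown sit.

The compounds shown do not tell whether the ring itself counts or only the carbons it carries. A cyclopentyl group, a cycloheptyl group or a longer chain such as hexyl on the same nitrogen would help to separate the two.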